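A few compounds are considered here, and "the series" means these few. Any claim that something is new, unique, unknown or untested is made for them only; others in the source may bear on it.

For the measured compounds named here, in a functional assay on CCRF-CEM cells (Homo sapiens) for cytotoxicity (a lower number here means a stronger inhibitor of growth, a higher number a weaker inhibitor of growth), compound 1 `CCCCCCNC(=O)c1cc(NCc2cc(O)ccc2O)ccc1O` gives 560 nM, the lower of the two numbers measured so far. Going by the values given here, the only other measured compound, compound 2 `O=C(NCc1ccccc1)c1cc(NCc2cc(O)ccc2O)ccc1O`, gives 3200 nM.

The next compound to be tested is compound 3 `CCCCCCCCCCCCNC(=O)c1cc(NCc2cc(O)ccc2O)ccc1O`. It keeps the core of compound 1 and extends the chain on the amide: hexyl in place of hydrogen on a saturated chain carbon, six bonds along the chain from an amide-type nitrogen. In words, hexyl takes the place of hydrogen on a saturated chain carbon, six bonds along the chain from an amide-type nitrogen.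

Among the compounds with values here, only one measured step bears on this change: a 5.7-fold higher number from compound 1 to compound 2 (0.76 log units; beyond the scatter). There, phenyl stands in place of pentyl on the same side of the molecule. That step is modest but beyond the scatter, so changes in this part of the molecule can shift the number. However, it swaps part of a chain for a ring, so it says nothing direct about a longer chain, and no measured pair tests chain length.

A small move toward a higher number is therefore expected, with real uncertainty in either direction. The expected step is a 1.6-fold higher number from compound 1 to compound 3 (0.21 log units; within the scatter). The estimate for compound 3 is 900 nM, with an expected range of 200 nM to 4000 nM.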

Compound 3, concentration for 50% growth inhibition: 340 nM
Beside the measured number, compound 3's estimate is 2.6-fold (0.42 log units) above it; the measured number falls inside the stated range.
By their numbers in this assay, from the lowest: compounds 3 and 1 (each within the scatter of the next); then compound 2.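

In this assay, adding hexyl on a saturated chain carbon, six bonds along the chain from an amide-type nitrogen, gives a 1.6-fold lower number from compound 1 to compound 3 (0.22 log units; within the scatter), so this read-out does not separate the two compounds. This is the first pair shown that tests chain length on the amide, and it shows that this part of the molecule accepts six more carbons with no change beyond the scatter, whereas the only earlier step here, with phenyl in place of pentyl, gave a 5.7-fold higher number from compound 1 to compound 2 (0.76 log units; beyond the scatter). No measurement shown here offers an explanation for this result.

With only two chain lengths shown, it remains open whether a chain of intermediate length such as octyl, or a longer chain than that of compound 3, would stay in the same range or leave it. Going by these compounds, it is also open how the number would respond to a chain carrying an amine or a carboxylic acid, and whether the match between compound 1 and compound 3 would hold in other cell lines.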